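Replacing the 1-bromoethyl group of compound 1

The compounds below may be only part of what the source reports. "The series", "measured", "known", "first", "only" and "open" are said of these compounds alone.

Measured in a functional assay on CCRF-CEM cells (Homo sapiens) for antiproliferative activity, read by trypan blue exclusion, with a stated time of 72 h; on this read-out higher numbers stand for weaker inhibition and lower numbers for stronger inhibition:
compound 1 `CC(Br)C(=O)Nc1ccc(F)c(C(=O)NC(N)=O)c1`: 520 nM
compound 2 `CC(Br)C(=O)Nc1ccc(Br)c(C(=O)NC(N)=O)c1`: 7630 nM

Compound 1 stands lowest of the two numbers, making it the stronger inhibitor of this pair. Compound 3 `NC(=O)NC(=O)c1cc(NC(=O)CCl)ccc1F` has not yet been measured. Its difference from compound 1 lies on a carbonyl carbon, with chloromethyl in place of 1-bromoethyl on a carbonyl carbon.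

Among the measured compounds shown here, the only measured step, a 15-fold higher number from compound 1 to compound 2 (1.17 log units; beyond the scatter), is large and beyond the scatter. However, it replaces fluoro with bromo on an aromatic carbon, so it bears only indirectly on this change. For the measured compounds named here, no measured step covers the group on the carbonyl carbon. Going by the values given here, compound 1, at 520 nM, holds the lowest number so far, so a moderate step towards a higher number in this assay is expected, though this is uncertain. The expected change is a 2.3-fold higher number from compound 1 to compound 3 (0.36 log units; beyond the scatter). For compound 3 the estimated value is 1200 nM, within an expected range of 250 nM to 6000 nM.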

Compound 3, half-maximal inhibitory concentration: 7680 nM
Beside the measured number, compound 3's estimate is 6.4-fold (0.81 log units) below it; measured number above the stated range.
By their numbers in this assay, from the lowest: compound 1; then compounds 2 and 3 (each within the scatter of the next).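

In this assay the group on the carbonyl carbon now has a measured step of its own: chloromethyl in place of 1-bromoethyl gives a 15-fold higher number from compound 1 to compound 3 (1.17 log units; beyond the scatter), large and beyond the scatter. The core of compound 1 is thus sensitive to change at this place as well as on the aromatic carbon, where bromo in place of fluoro gives a 15-fold higher number from compound 1 to compound 2 (1.17 log units; beyond the scatter) as the step of the same size. Nothing measured accounts for the size of the step at the carbonyl carbon.

This single change swaps bromine for chlorine and shortens the group by one carbon, and the compounds shown do not separate the two. Bromomethyl or 1-chloroethyl at this place would pull them apart, while an ethyl group or an amine would show what the halogen itself contributes.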